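The compounds below may be only part of what the source reports. "The series", "measured", "known", "first", "only" and "open" are said of these compounds alone.

Measured so far:
- compound 1, `CN(c1ncco1)c1cnc(NCc2c(F)ccc3c2CCO3)n2cnnc12`: 11 mL.min-1.g-1
- compound 2, `CN(C)C(=O)c1cc(-c2cnc(NCc3c(F)ccc4c3CCO4)c3cn[nH]c(=O)c23)n(C)n1`: 21 mL.min-1.g-1

Both compounds were tested in an ADME assay on microsomes from liver (Homo sapiens) for metabolic stability, read by LC-MS, using NADPH, with stated times of 5 min and 30 min, tested at 1 uM; a higher number here means faster removal of the compound, a lower number slower removal. Compound 1 gives 11 mL.min-1.g-1, the lowest of the two numbers, and compound 2 gives 21 mL.min-1.g-1; the gap between them lies within the scatter of this assay, so the two cannot be told apart.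

Compound 3, `O=C1CC2(CC2)CN1c1cnc(NCc2c(F)ccc3c2CCO3)n2cnnc12`, has not yet been measured. It shares the core of compound 1 and differs from it in one place: a group of 8 heavy atoms (6 carbon, 1 nitrogen, 1 oxygen; one three-membered non-aromatic ring of carbon only, one five-membered non-aromatic ring with 1 hetero atom) in place of a group of 7 heavy atoms (4 carbon, 2 nitrogen, 1 oxygen; one five-membered aromatic ring with 2 hetero atoms), on an aromatic carbon. For the measured compounds named here, no step between two measured compounds of this kind exists, so there is nothing here that says how such a change moves the number in this assay.

With only the value of compound 1 as a starting point, compound 3 is expected to stay close to it, with a change no larger than the usual scatter, because compound 1 gives 11 mL.min-1.g-1 and nothing measured points away from that. For compound 3 the estimate is 9 mL.min-1.g-1, with a range from 4 mL.min-1.g-1 to 22 mL.min-1.g-1, which means an expected step of a 1.2-fold lower number from compound 1 to compound 3 (0.09 log units; within the scatter).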

Compound 3, intrinsic clearance in microsomes in the Homo sapiens assay: < 3 mL.min-1.g-1
Compound 3 was reported as a limit (the forecaster's own chance of this, stated with the estimate: 15%); middle value at least 3.0-fold (0.47 log units) away from the limit.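

For the compounds shown here, in the Homo sapiens assay, putting the group with one three-membered carbon ring and one five-membered non-aromatic ring in place of methyl(1,3-oxazol-2-yl)amino gives an at least 3.6-fold lower number from compound 1 to compound 3 (0.56 log units; beyond the scatter), the first step here that isolates a single change, and it shows that the group on this aromatic carbon can move the clearance by more than the scatter while the rest of the molecule stays the same. For compound 3, the reading of < 3 mL.min-1.g-1 is a limit of the assay and not a number. The same change also comes with a gain in a physicochemical assay for solubility, in phosphate buffer, measured as thermodynamic solubility, with a stated time of 24 h, at pH 6.9 (on this read-out lower numbers stand for lower solubility and higher numbers for higher solubility), rather than a loss, so here slower removal and higher solubility appear together in one step: the measured solubility of compound 1, 53000 nM, and of compound 3, 175000 nM, a 3.3-fold higher number (0.52 log units; beyond the scatter). In the physicochemical assay compound 1 gives 53000 nM and compound 3 gives 175000 nM.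

This single pair cannot show which feature of the entering group goes with these results: the three-membered ring, the five-membered ring or the double bond outside aromatic rings. It also leaves open whether a different group on this carbon, such as a plain dimethylamino group or a morpholine, would give similar numbers in both assays.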